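Removing the Drawn Configuration at the Stereocentre of Compound 3

A few compounds are considered here, and "the series" means these few. Any claim that something is new, unique, unknown or untested is made for them only; others in the source may bear on it.

In a functional assay on the whole organism (spleen, spleen) with Rattus norvegicus as the target (a lower number here means that less compound is needed, a higher number that more compound is needed for the effect), compound 3 `CCCCCCCOc1ccc(CC[C@](N)(CO)CCO)cc1` gives 4.2 mg/kg, the highest of the three numbers. Compound 1 `CCCCCCCOc1ccc(CCC(N)(CO)CCC)cc1` gives 3.1 mg/kg and compound 2 `CCCCCCCOc1ccc(CC[C@@](N)(CO)CCC)cc1` gives 0.63 mg/kg; the step of a 6.7-fold higher number from compound 2 to compound 3 (0.82 log units; beyond the scatter) is beyond the scatter. Compound 4 `CCCCCCCOc1ccc(CCC(N)(CO)CCO)cc1` differs from compound 3 only in this: the two compounds have the same atoms and bonds; at least one stereo element is drawn with a configuration in one of them and without one in the other: 1 of 1 stereo elements differ; a stereocentre at a saturated chain carbon is drawn R in compound 3 and without a configuration in compound 4. Among the measured compounds shown here, the one measured step that bears on it is a 4.9-fold lower number from compound 1 to compound 2 (0.69 log units; beyond the scatter), which points the other way, because of the fact that one of compounds 1 and 2 is drawn with a defined configuration and the other without, at the place where they differ. Reversing that direction, compound 4 is expected to need a higher dose than compound 3, with a step of about a 2.9-fold higher number from compound 3 to compound 4 (0.46 log units; beyond the scatter) in this assay. The estimate for compound 4 is 12 mg/kg, within a range of 4 mg/kg to 40 mg/kg.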

Compound 4, dose for 50% inhibition: 0.038 mg/kg
The estimate for compound 4 lay 320-fold (2.50 log units) above the measured number; measured number outside the range, below it.
By their numbers in this assay, from the lowest: compound 4; then compound 2; then compounds 1 and 3 (each within the scatter of the next).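

Dropping the drawn configuration does not act alike on every compound: a 110-fold lower number from compound 3 to compound 4 (2.04 log units; beyond the scatter), opposite in direction to a 4.9-fold lower number from compound 1 to compound 2 (0.69 log units; beyond the scatter). The effect of hydroxy in place of methyl also reverses, with an 82-fold lower number from compound 1 to compound 4 (1.91 log units; beyond the scatter) for the undrawn compounds against a 6.7-fold higher number from compound 2 to compound 3 (0.82 log units; beyond the scatter) for the drawn ones. Compound 4 also falls below a drawn compound, with a 17-fold lower number from compound 2 to compound 4 (1.22 log units; beyond the scatter).

As far as these compounds go, it remains open which drawn form of compound 4 carries the effect in this assay. Also open, from the compounds shown here alone, is how an amine or a longer chain would compare with the hydroxy at this chain end.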